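Swapping Dipropylamino for Diisobutylamino on the Side Chain

The source may hold more compounds than are shown below. What is called first, only, known or untested is meant among the compounds shown, and "the series" means these compounds.

For the measured compounds named here, compound 1 `CCCN(CCC)CC(C1CCCCC1)N1CCN(C(=O)[C@@H]2CN(C(C)(C)C)C[C@H]2c2ccc(F)cc2F)CC1` was tested in an assay on CHO cells for displacement of a labelled ligand from Melanocortin receptor 4 (Homo sapiens) (on this read-out lower numbers stand for stronger inhibition and higher numbers for weaker inhibition), where compound 1 gives 200 nM; that is the only number recorded for it, two further entries having returned no single value. Two relatives sharing the same core were measured alongside it. Compound 2 `CC(C)N(CC(C1CCCCC1)N1CCN(C(=O)[C@@H]2CN(C(C)(C)C)C[C@H]2c2ccc(F)cc2F)CC1)C(=O)c1ncccn1` gives 130 nM; 35 nM (2 entries) in this assay, and compound 3 `CC(=O)N(CC(C1CCCCC1)N1CCN(C(=O)[C@@H]2CN(C(C)(C)C)C[C@H]2c2ccc(F)cc2F)CC1)C(C)C` gives 28 nM; 29 nM (2 entries). Both differ from compound 1 in more than one place, so their numbers are shown here only for what they are; the spread within compound 2 is visible in the several entries of compound 2 in this assay, 130 nM; 35 nM (2 entries), while the several entries of compound 3 in this assay, 28 nM; 29 nM (2 entries) shows close agreement for compound 3.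

The change now followed is a single one: compound 4 `CC(C)CN(CC(C)C)CC(C1CCCCC1)N1CCN(C(=O)[C@@H]2CN(C(C)(C)C)C[C@H]2c2ccc(F)cc2F)CC1` carries diisobutylamino in place of dipropylamino on a saturated chain carbon, two bonds along the chain from an amine nitrogen in a ring and a saturated ring carbon. Each propyl arm gains one branching carbon, the nitrogen stays, and no ring, donor, acceptor or charge is added or lost. Going by the values given here, no measured pair in this set isolates a change of that kind, so the expectation rests on the modest size of the change alone. The step from compound 1 to compound 4 in this assay is expected to be small, a 1.3-fold higher number from compound 1 to compound 4 (0.10 log units; within the scatter), lying within the usual scatter or at most a slight weakening. Compound 4 is therefore estimated at 250 nM in this assay, with a plausible range from 80 nM to 800 nM.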

Compound 4, half-maximal inhibitory concentration: 1900 nM
The estimate for compound 4 lay 7.6-fold (0.88 log units) below the measured number; measured number outside the range, above it.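

In this assay, this position on the side chain turns out to be sensitive to a change that looks minor on paper: diisobutylamino in place of dipropylamino gives a 9.5-fold higher number from compound 1 to compound 4 (0.98 log units; beyond the scatter), although the group only grows from 7 heavy atoms to 9 and no ring, donor, acceptor or charge is gained or lost. For the compounds shown here, the earlier compounds could not show this; each differs from compound 1 in more than one place, so this is the first step here that isolates the groups on the side-chain nitrogen. The step rests on one number for each of the two compounds, and repeated entries for a relative can spread widely: the several entries of compound 2 in this assay, 130 nM; 35 nM (2 entries)

Going by these compounds alone, the single pair cannot separate the effect of branching in the two arms from that of their added carbons. A straight-chain dibutylamino group, which would add carbons without branching, or a shorter diethylamino group at the same place on the chain would show which of the two matters and whether the number improves as the arms shrink.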